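Hydroxy in place of hydrogen on two different cores

The source may hold more compounds than are shown below. What is called first, only, known or untested is meant among the compounds shown, and "the series" means these compounds.

Of the compounds shown here, three have been measured in a functional assay on cells (Mus musculus) for cytotoxicity, read by MTT assay, with a stated time of 24 h, tested at 10 uM; on this read-out lower numbers stand for a weaker effect and higher numbers for a stronger effect at the one concentration tested. Compound 1 `COc1cc(/C=N/NC(=O)OCc2ccccc2)ccc1O` gives 73% in this assay. Compound 2 `COc1cc(/C=N/Nc2nc3ccccc3s2)ccc1O` gives 61%, and compound 3 `COc1cc(/C=N/Nc2nc3ccccc3s2)cc(O)c1O` gives 54%. The number for compound 1 is the highest of the three, and its gaps to compound 2 and to compound 3 both lie beyond the scatter. How the core of compound 1 differs from the core of compound 2 is not broken down here.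

Within the second core, the change from compound 2 to compound 3 is hydroxy in place of hydrogen on an aromatic carbon. It gives a number 7 percentage points lower from compound 2 to compound 3 (within the scatter), a step that stays within the scatter.

Compound 4 `COc1cc(/C=N/NC(=O)OCc2ccccc2)c(O)cc1O` is not yet measured. It differs from compound 1 by hydroxy in place of hydrogen on an aromatic carbon. For the measured compounds named here, this is the same kind of change as the one from compound 2 to compound 3, but not the same: in compound 3 the entering hydroxy sits ortho to a hydroxy group, meta to a large group and meta to a methoxy group, whereas in compound 4 it sits ortho to a large group, meta to a hydroxy group and para to a methoxy group, and the core is a different one.

Going by the values given here, for compound 4 the step of a number 6 percentage points lower from compound 1 to compound 4 (within the scatter) in this assay is expected to be small, resting on the only measured precedent, which is the change from compound 2 to compound 3 with a number 7 percentage points lower from compound 2 to compound 3 (within the scatter). The number for compound 4 in this assay is therefore estimated at 67%, with an expected range from 54% to 80%.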

Compound 4, a percentage reported as activity, at one concentration (the size of the read-out at that concentration, not a potency): 79%
Compound 4: middle estimate off by 12 percentage points, on the low side, and the stated range covers the measured number.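

In this assay, hydroxy in place of hydrogen on an aromatic carbon of the core of compound 1 gives a number 6 percentage points higher from compound 1 to compound 4 (within the scatter), and this step does not differ from the earlier one on the other core: the same change on two cores in this assay, a number 7 percentage points lower (within the scatter) from compound 2 to compound 3 and a number 6 percentage points higher (within the scatter) from compound 1 to compound 4, 13 percentage points apart, within the scatter of two such steps

Read together, the two steps show that on both cores this change leaves the number within the scatter of the parent compound, so the small step seen on one core carried over to the other in these two cases. For the compounds shown here, they do not show that the change is without effect in general or that its outcome is independent of the core, since there are only two steps and the entering hydroxy stands at a different place on each core, so that core and place cannot be separated here.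

The compounds shown leave open how an amine or a carboxylic acid would read at the place taken by the entering hydroxy, and whether a longer chain such as ethoxy in place of methoxy would give a step beyond the scatter on either core. They also leave open whether the two cores would still read alike with either hydroxy placement swapped, with the entering hydroxy of compound 3 placed on the core of compound 1 and that of compound 4 on the core of compound 2.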